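Cyanoguanidine returns on a shorter chain

A few compounds are considered here, and "the series" means these few. Any claim that something is new, unique, unknown or untested is made for them only; others in the source may bear on it.

Measured in a functional assay on the whole organism with Rattus norvegicus as the target, at a dose of 100 mg/kg; a lower number here means less inhibition, a higher number more inhibition at the dose given (going by the name of the read-out):
compound 1 `N#CNC(=N)NCCCCCn1nc(-c2ccccc2)ccc1=O` gives 31%;
compound 2 `N/C(S)=N/CCCCn1nc(-c2ccccc2)ccc1=O` gives 72%;
compound 3 `CC/N=C(\S)NCCCCn1nc(-c2ccccc2)ccc1=O` gives 67.7%.

Compound 3 stands second highest of the three numbers. Its nearest neighbour is compound 2, with a number 4.3 percentage points lower from compound 2 to compound 3 (within the scatter); the furthest is compound 1, with a number 36.7 percentage points higher from compound 1 to compound 3 (beyond the scatter). Compound 4 `N#CNC(=N)NCCCn1nc(-c2ccccc2)ccc1=O` carries a group of 6 heavy atoms (2 carbon, 4 nitrogen; no ring) in place of a group of 7 heavy atoms (4 carbon, 2 nitrogen, 1 sulfur; no ring), on a saturated chain carbon, three bonds along the chain from an aromatic nitrogen. Among the compounds with values here, the step that bears on this change is the one between compound 1 and compound 3, which ran the other way and was large. Within the data shown here, the group now sits three bonds along the chain from the aromatic nitrogen rather than four, and no measured step tells how that matters. The expected step is therefore large and downward, a number 33.7 percentage points lower from compound 3 to compound 4 (beyond the scatter). Compound 4 is estimated at 34%, within 15% to 55%.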

Compound 4, a percentage reported as inhibition, in the whole organism at one dose (the size of the read-out at that dose, not a potency): 33.3%
Estimate against measurement, compound 4: 0.7 percentage points above; the range from low to high includes it.
By their numbers in this assay, from the lowest: compounds 1 and 4 (each within the scatter of the next); then compounds 3 and 2 (each within the scatter of the next).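

With the cyanoguanidine on the shorter chain, this assay gives a number 34.4 percentage points lower from compound 3 to compound 4 (beyond the scatter) and a number 38.7 percentage points lower from compound 2 to compound 4 (beyond the scatter) (both beyond the scatter as printed), so shortening the chain does not bring this group up to the sulfur-bearing compounds. Shortening the chain with the cyanoguanidine kept in place gives a number 2.3 percentage points higher from compound 1 to compound 4 (within the scatter) and so separates neither chain length from the other at this dose. No evidence is at hand that explains the gap between these end groups. Still open, going by these compounds, is whether a sulfur-bearing end group holds its number three bonds along the chain from the aromatic nitrogen, and how an amine or a urea would read there.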